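The source may report more compounds than this note shows. Statements on the series, on what has been measured and on what is new or still open speak of the compounds shown alone.

Series notes. Compound 1 `CC(C)(C)OC(=O)N1CCC[C@H]1C(=O)N1CCC(NS(=O)(=O)c2cc(S(=O)(=O)c3ccccc3)ccc2C(F)(F)F)CC1` carries a tert-butoxy group on a carbonyl carbon of the shared core; in an assay on isolated protein for binding affinity to secreted frizzled-related protein 1 (Homo sapiens), read by fluorescence (a lower number here means a stronger inhibitor, a higher number a weaker inhibitor), compound 1 gives 60 nM. Compound 2 `CC(C)C(=O)N1CCC[C@H]1C(=O)N1CCC(NS(=O)(=O)c2cc(S(=O)(=O)c3ccccc3)ccc2C(F)(F)F)CC1` gives 40 nM and compound 3 `O=C([C@@H]1CCCN1C(=O)c1ccncc1)N1CCC(NS(=O)(=O)c2cc(S(=O)(=O)c3ccccc3)ccc2C(F)(F)F)CC1` gives 70 nM, so compound 1 sits among three numbers that all lie within the scatter of one another. Isopropyl in place of tert-butoxy gives a 1.5-fold lower number from compound 1 to compound 2 (0.18 log units; within the scatter), pyridin-4-yl in place of tert-butoxy gives a 1.2-fold higher number from compound 1 to compound 3 (0.07 log units; within the scatter), and a 1.8-fold higher number from compound 2 to compound 3 (0.24 log units; within the scatter) likewise stays within the scatter. Compound 4 `O=C([C@@H]1CCCN1C(=O)Nc1ccccc1)N1CCC(NS(=O)(=O)c2cc(S(=O)(=O)c3ccccc3)ccc2C(F)(F)F)CC1` changes the same carbonyl carbon once more: anilino in place of tert-butoxy on a carbonyl carbon Both earlier steps at this position bear on it and neither left the scatter, so no step beyond the scatter is expected. The expected step is no change at the digits printed from compound 1 to compound 4 (within the scatter). Compound 4 is therefore estimated at 60 nM, with a range from 25 nM to 150 nM.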

Compound 4, half-maximal inhibitory concentration: 20 nM
For compound 4 the middle estimate is 3.0-fold (0.48 log units) above the measured one; the measured number lies below the stated range.
By their numbers in this assay, from the lowest: compounds 4, 2, 1 and 3 (each within the scatter of the next, the first and the last beyond it).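

Going by these compounds alone, at this carbonyl carbon, anilino gives the first steps beyond the scatter: in place of tert-butoxy it gives a 3.0-fold lower number from compound 1 to compound 4 (0.48 log units; beyond the scatter), and in place of pyridin-4-yl it gives a 3.5-fold lower number from compound 3 to compound 4 (0.54 log units; beyond the scatter). Anilino in place of isopropyl still gives a 2.0-fold lower number from compound 2 to compound 4 (0.30 log units; within the scatter), which stays within the scatter, so anilino is separated from only two of the three earlier groups. No evidence is available that accounts for these steps.

On these data alone, whether the result depends on the hydrogen on the anilino nitrogen or on the phenyl ring remains open. N-methylanilino and benzylamino on the same carbonyl carbon would separate these two readings.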